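Notes: propanoyl to (2-fluorophenyl)carbonyl

A few compounds are considered here, and "the series" means these few. Any claim that something is new, unique, unknown or untested is made for them only; others in the source may bear on it.

Values so far in an ADME assay on L02 cells (Homo sapiens) for cytotoxicity, read by MTT assay, with a stated time of 72 h (a lower number here means a stronger inhibitor, a higher number a weaker inhibitor), for the measured compounds:
- compound 1 `CCN1C/C(=C\c2cc(OC)c(OC)c(OC)c2)C(=O)/C(=C/c2cc(OC)c(OC)c(OC)c2)C1` gives 12800 nM
- compound 2 `CCC(=O)N1C/C(=C\c2cc(OC)c(OC)c(OC)c2)C(=O)/C(=C/c2cc(OC)c(OC)c(OC)c2)C1` gives 4200 nM

Compound 2 at 4200 nM has the lower of the two numbers in this assay and compound 1 stands above it. Within the data shown here, the one measured step of a 3.0-fold lower number from compound 1 to compound 2 (0.48 log units; beyond the scatter) comes with propanoyl in place of ethyl on an amine nitrogen in a ring and is modest.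

Compound 3 `COc1cc(/C=C2\CN(C(=O)c3ccccc3F)C/C(=C\c3cc(OC)c(OC)c(OC)c3)C2=O)cc(OC)c1OC` is still unmeasured. Its change from compound 2 is 2-fluorophenyl in place of ethyl on a carbonyl carbon and reads in words as 2-fluorophenyl in place of ethyl on a carbonyl carbon.

Among the measured compounds shown here, only the step of a 3.0-fold lower number from compound 1 to compound 2 (0.48 log units; beyond the scatter) bears on this, and only loosely. For the measured compounds named here, compound 3 keeps the carbonyl that compound 2 carries, and no measured compound has a ring on that carbonyl carbon. With so little to go on, no step beyond the scatter is expected in this assay and the lean is slight, toward a lower number. The estimated step is a 1.4-fold lower number from compound 2 to compound 3 (0.15 log units; within the scatter). For compound 3 the expected value is 3000 nM with an estimated range from 1000 nM to 9000 nM in this series.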

Compound 3, half-maximal inhibitory concentration: 4400 nM
Beside the measured number, compound 3's estimate is 1.5-fold (0.17 log units) below it; low and high end bracket the measured number.
By their numbers in this assay, from the lowest: compounds 2 and 3 (each within the scatter of the next); then compound 1.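

In this assay, the ethyl on the carbonyl carbon and the 2-fluorophenyl that enters there read alike (a 1.0-fold higher number from compound 2 to compound 3 (0.02 log units; within the scatter)), although the entering group brings 7 heavy atoms and one six-membered aromatic ring where the leaving group has 2 heavy atoms and no ring. Among these compounds, the carbonyl carbon therefore carries either group with no difference beyond the scatter, and the step from ethyl on the amine nitrogen in a ring to the acyl group also persists with the aromatic ring in place (a 2.9-fold lower number from compound 1 to compound 3 (0.46 log units; beyond the scatter)). No independent measurement on these compounds bears on why the propanoyl and (2-fluorophenyl)carbonyl groups read alike.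

With one ring-bearing group on this carbonyl carbon, the contribution of the fluorine cannot be separated from that of the phenyl ring, and plain phenyl would be the direct comparison. Going by these compounds, whether the same flat reading holds for a longer chain, an amine or a carboxylic acid on the carbonyl carbon remains open.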